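The compounds below may be only part of what the source reports. "The series", "measured", "known", "first", "only" and "open" are said of these compounds alone.

In a physicochemical assay for lipophilicity (on this read-out higher numbers stand for higher lipophilicity and lower numbers for lower lipophilicity), three compounds have been measured so far:

Compound 1, `CCN1CCN(c2ccc(NC3=CC(=O)C(C(=O)OC)C(c4ccccc4)C3)cc2)CC1`, gives 4.39.
Compound 2, `CCOC(=O)C1C(=O)C=C(Nc2cccc(N3CCN(C)CC3)c2)CC1c1ccccc1`, gives 4.37.
Compound 3, `CCOC(=O)C1C(=O)C=C(Nc2ccc(N3CCN(CC)CC3)cc2)CC1c1ccccc1`, gives 4.77.

Compound 3 and compound 1 differ in a single place: hydrogen in place of methyl on a saturated chain carbon bound to an oxygen next to a carbonyl group. In this assay that change gave a number 0.38 log units lower from compound 3 to compound 1 (beyond the scatter). Compound 4, `COC(=O)C1C(=O)C=C(Nc2cccc(N3CCN(C)CC3)c2)CC1c1ccccc1`, has not yet been measured. It arises from compound 2 by the same change, (hydrogen in place of methyl on a saturated chain carbon bound to an oxygen next to a carbonyl group), made on a different core; the difference between the cores of compound 2 and compound 3 is not broken down here. Among the measured compounds shown here, because the one measured example of this change, a number 0.38 log units lower from compound 3 to compound 1 (beyond the scatter), was a modest drop, compound 4 is expected to come out a number 0.38 log units lower from compound 2 to compound 4 (beyond the scatter) from compound 2. The estimate for compound 4 in this assay is 3.99, expected to fall between 3.7 and 4.3.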

Compound 4, partition coefficient: 3.99
For compound 4 middle estimate and measured number coincide at the digits printed; the range from low to high includes it.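

In this assay, replacing ethoxycarbonyl with methoxycarbonyl gave a number 0.38 log units lower from compound 2 to compound 4 (beyond the scatter) and, on the other core, a number 0.38 log units lower from compound 3 to compound 1 (beyond the scatter) in the earlier pair, so the step had the same size on both cores. This shows that the change carried over between these two cores, but two pairs are too few to set a rule for other cores in the series. No measurement shown here explains why the two steps match.

The compounds shown leave open what this assay gives for a longer chain, such as propoxycarbonyl, in that place. They also leave open how a free carboxylic acid there would compare.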